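Swapping the Chain on the Ring Nitrogen of Compound 1

This account rests on a few compounds, and the source may have more. Where it says the series, first, only, none or still open, it means among the compounds named here.

Within the data shown here, compound 1 `CNC(=O)Nc1ccc(-c2nc(N3CC4CCC(C3)O4)c3cnn(CCN(C)C)c3n2)cc1` is one of two compounds measured so far in a functional assay on LNCaP cells (Homo sapiens) for cytotoxicity (a lower number here means a stronger inhibitor, a higher number a weaker inhibitor), and in this assay compound 1 gives 400 nM, the highest of the two numbers. Compound 2 `CCn1ncc2c(N3CC4CCC(C3)O4)nc(-c3ccc(NC(=O)NC)cc3)nc21` differs from it in one place, and in this assay compound 2 gives 70 nM. The step between them is a 5.7-fold lower number from compound 1 to compound 2 (0.76 log units; beyond the scatter), brought about by hydrogen in place of dimethylamino on a saturated chain carbon, two bonds along the chain from an aromatic nitrogen.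

Compound 3 `CNC(=O)Nc1ccc(-c2nc(N3CC4CCC(C3)O4)c3cnn([C@H]4CC[C@@H](O)CC4)c3n2)cc1` has not yet been measured. It differs from compound 1 by 4-hydroxycyclohexyl in place of 2-(dimethylamino)ethyl on an aromatic nitrogen. Among the measured compounds shown here, the group that leaves is the same 2-(dimethylamino)ethyl whose trimming in the step from compound 1 to compound 2 gave a lower number, so that step is the only guide here, and it points toward a lower number of modest size once more. The entering 4-hydroxycyclohexyl is a different group from the ethyl of compound 2, with a ring and a hydrogen-bond donor, so the size remains uncertain. Compound 3 is therefore expected to show a step of a 3.6-fold lower number from compound 1 to compound 3 (0.56 log units; beyond the scatter), giving an estimate of 110 nM, within 30 nM to 400 nM.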

Compound 3, half-maximal inhibitory concentration: 20 nM
The estimate for compound 3 lay 5.5-fold (0.74 log units) above the measured number, and the stated range ends above it.
By their numbers in this assay, from the lowest: compound 3; then compound 2; then compound 1.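

The position on the aromatic nitrogen does more than reward the loss of the dimethylamino group: in this assay, 4-hydroxycyclohexyl in place of 2-(dimethylamino)ethyl gives a 20-fold lower number from compound 1 to compound 3 (1.30 log units; beyond the scatter), a large step. The earlier pair showed only that trimming the chain to ethyl lowers the number, whereas the further change from ethyl to 4-hydroxycyclohexyl gives a 3.5-fold lower number from compound 2 to compound 3 (0.54 log units; beyond the scatter), so the identity of the entering group matters here and a bigger group with a ring is not penalised. Nothing available explains why this group gives the lowest number of the three.

The 4-hydroxycyclohexyl group brings a six-membered ring, a hydroxyl and two defined stereocentres all at once, and the compounds shown cannot say which of these carries the gain. A plain cyclohexyl on the same nitrogen would separate the ring from the hydroxyl, and the isomer with the hydroxyl on the opposite face of the ring would show whether its arrangement counts.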